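A few compounds are considered here, and "the series" means these few. Any claim that something is new, unique, unknown or untested is made for them only; others in the source may bear on it.

Going by the values given here, compound 1 `CN1CCN(S(=O)(=O)c2ccc(N3CCC=N3)cc2)c2ccccc21` is the only compound here with a number in hand: in a functional assay on MCF7 cells (Homo sapiens) for antiproliferative activity, read by fluorescence and SYBR Green assay, with a stated time of 24 h (on this read-out lower numbers stand for stronger inhibition and higher numbers for weaker inhibition), compound 1 gives 7 nM. Compound 2 `CCCN(c1ccccc1)S(=O)(=O)c1ccc(N2CCCC2=O)cc1` is known in this assay only as a limit of the assay, not as a number, at > 5000 nM. That point is the limit of > 5000 nM in this assay, at which 1 of the 2 values shown sits. Compound 3 `CN1CCN(S(=O)(=O)c2ccc(N3CCCC3)cc2)c2ccccc21` has not been measured yet. It differs from compound 1 in one place: a group of 5 heavy atoms (4 carbon, 1 nitrogen; one five-membered non-aromatic ring with 1 hetero atom) in place of a group of 5 heavy atoms (3 carbon, 2 nitrogen; one five-membered non-aromatic ring with 2 hetero atoms), on an aromatic carbon. The change sits on an aromatic carbon, para to a large group. Among the compounds with values here, no measured step connects compounds that differ in one place, so the size of this step has to be judged from compound 1 alone. The group that leaves carries a double bond outside aromatic rings and a second acceptor, and the pyrrolidin-1-yl that enters has neither, so a modest loss in this assay is expected, the step from compound 1 to compound 3 being estimated as a 3.6-fold higher number from compound 1 to compound 3 (0.55 log units; beyond the scatter). Compound 3 is therefore expected to give about 25 nM, with a likely span from 6 nM to 120 nM.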

Compound 3, half-maximal inhibitory concentration: 4 nM
Compound 3: middle estimate off by 6.3-fold (0.80 log units), on the high side, outside the stated range (below it).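

In this assay the exchange gives a 1.8-fold lower number from compound 1 to compound 3 (0.24 log units; within the scatter), so on this aromatic carbon, para to a large group, the pyrrolidin-1-yl and the ring with 2 hetero atoms cannot be told apart. The double bond outside aromatic rings and the second hydrogen-bond acceptor of the leaving group are therefore not needed here for a value of this order. Nothing shown accounts for this step.

Going by these compounds, both groups at this position are five-membered non-aromatic rings of equal heavy-atom count, so it remains open how a larger ring such as morpholin-4-yl, or an open-chain dimethylamino group, would read here. On these data alone, compound 2 gives > 5000 nM, which is a limit of the assay, and it differs from compound 1 in more than one place, so which of its changes matters also stays open.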